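The source may hold more compounds than are shown below. What is called first, only, known or untested is meant among the compounds shown, and "the series" means these compounds.

Compound 2 `CN(C(=O)NC(=O)c1ccccc1F)c1nc(C(F)(F)F)c(C(=O)N/N=C/c2cc(C(F)(F)F)cc(C(F)(F)F)c2)s1` gives 6.16 ug/mL in a functional assay on MCF7 cells (Homo sapiens) for inhibition, read by MTT assay, with a stated time of 72 h (on this read-out higher numbers stand for weaker inhibition and lower numbers for stronger inhibition), and compound 1 `CN(C(=O)NC(=O)c1ccc(F)c(F)c1)c1nc(C(F)(F)F)c(C(=O)N/N=C/c2ccc(C(F)(F)F)cc2)s1` gives 5.93 ug/mL in this assay, the two numbers lying within the usual scatter of each other. Compound 3 `CN(C(=O)NC(=O)c1c(F)cccc1F)c1nc(C(F)(F)F)c(C(=O)N/N=C/c2cc(C(F)(F)F)cc(C(F)(F)F)c2)s1` differs from compound 2 by fluoro in place of hydrogen on an aromatic carbon. Among the compounds with values here, no measured pair shows this change, so the step from compound 2 to compound 3 is expected to stay within the scatter, without a clear direction. Compound 3 is therefore expected to give about 5.5 ug/mL, with a range from 2.5 ug/mL to 12 ug/mL. This estimate means a step of a 1.1-fold lower number from compound 2 to compound 3 (0.05 log units; within the scatter).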

Compound 3, half-maximal inhibitory concentration: 6.85 ug/mL
Compound 3: the middle estimate sits 1.2-fold (0.10 log units) below what was measured, within the range that was stated.
By their numbers in this assay, from the lowest: compounds 1, 2 and 3 (each within the scatter of the next).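

Within the data shown here, the step from the 2-fluorophenyl to the 2,6-difluorophenyl group is the first single-place comparison in this assay (a 1.1-fold higher number from compound 2 to compound 3 (0.05 log units; within the scatter)). It shows that a second fluoro on this aromatic carbon, ortho to a large group, leaves the number within the scatter. Nothing measured here explains this result. The compounds shown leave open whether a methoxy group or an amine at this place would move the number beyond the scatter, and whether fluoro would act alike on the other phenyl ring.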